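The source may report more compounds than this note shows. Statements on the series, on what has been measured and on what is new or still open speak of the compounds shown alone.

Of the compounds shown here, three of a shared core have been measured in a functional assay on MCF7 cells (Homo sapiens) for cytotoxicity, read by MTT assay, with a stated time of 72 h; on this read-out lower numbers stand for stronger inhibition and higher numbers for weaker inhibition. Compound 1 `COC(=O)c1ccc(/C=C/C(=O)c2cc3cc(O)ccc3oc2=O)cc1` gives 1300 nM. Compound 2 `COc1cc(/C=C/C(=O)c2cc3cc(O)ccc3oc2=O)cc(OC)c1OC` gives 10900 nM. Compound 3 `COc1cccc(/C=C/C(=O)c2cc3ccc(O)cc3oc2=O)c1OC` gives 16600 nM, the highest number of the three; the gap between compound 3 and compound 2 lies within the scatter of this assay, so no order between those two can be read, while the gap between compound 3 and compound 1 lies beyond the scatter.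

Compound 4 `COc1cccc(COc2ccc3cc(C(=O)/C=C/c4cccc(OC)c4OC)c(=O)oc3c2)c1` is not yet measured. It differs from compound 3 in one place: 3-methoxybenzyl in place of hydrogen on an oxygen on an aromatic ring, that is, hydroxy becomes (3-methoxybenzyl)oxy. Within the data shown here, no measured pair shows this change, so its effect must be guessed. Because compound 3 sits at 16600 nM, and with nothing in the measured set to say which way a capped hydroxy moves the number, the step from compound 3 to compound 4 is expected to be small, a 1.4-fold lower number from compound 3 to compound 4 (0.14 log units; within the scatter), at most a modest gain and possibly none beyond the scatter. For compound 4 the expected value in this assay is 12000 nM, with a range from 3000 nM to 40000 nM.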

Compound 4, half-maximal inhibitory concentration: 35100 nM
Compound 4: middle estimate off by 2.9-fold (0.47 log units), on the low side; low and high end bracket the measured number.
By their numbers in this assay, from the lowest: compound 1; then compounds 2 and 3 (each within the scatter of the next); then compound 4.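

In this assay, among these compounds, turning hydroxy into (3-methoxybenzyl)oxy on this oxygen gives a 2.1-fold higher number from compound 3 to compound 4 (0.33 log units; beyond the scatter), the first single change that can be read in this set. It shows that this position is not indifferent to the change: capping the hydroxy with 3-methoxybenzyl moves the number towards weaker inhibition, by a modest step. No measured information accounts for this rise.

Going by these compounds, it remains open whether the rise follows from the loss of the hydrogen on that oxygen or from the 3-methoxybenzyl group itself, a question that a methyl or an unsubstituted benzyl on the same oxygen would address. Also open, on these data alone, are whether a chain ending in an amine or a carboxylic acid on this oxygen would move the number the other way, and whether the same change shifts the number similarly on compound 1 or compound 2.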